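Swapping the Aryl Group on the Shared Core

The source may report more compounds than this note shows. Statements on the series, on what has been measured and on what is new or still open speak of the compounds shown alone.

Compound 2 `COc1cccc(-c2noc(COc3ccc(CCC(=O)O)cc3)n2)c1` is the higher of the two numbers recorded so far: in a functional assay on CHO cells for agonist activity at Free fatty acid receptor 1 (Homo sapiens), read by FLIPR and calcium flux, in the presence of a further agent that is not named here (a higher number here means that more compound is needed for the effect, a lower number that less compound is needed), compound 2 gives 2670 nM. Among the compounds with values here, compound 1 `O=C(O)CCc1ccc(OCc2nc(-c3ccc(F)cc3)no2)cc1` gives 680 nM, and the change a 3.9-fold higher number from compound 1 to compound 2 (0.59 log units; beyond the scatter) marks the only measured step that bears on the next move. Compound 3 `Cc1cc(-c2noc(COc3ccc(CCC(=O)O)cc3)n2)ccc1F` differs from compound 2 by 4-fluoro-3-methylphenyl in place of 3-methoxyphenyl on an aromatic carbon. Within the data shown here, since compound 3 restores the fluorine that compound 1 carries, a lower number is expected because a 3.9-fold higher number from compound 1 to compound 2 (0.59 log units; beyond the scatter) was the only step seen, and its reversal is expected: a 3.3-fold lower number from compound 2 to compound 3 (0.52 log units; beyond the scatter). For compound 3 a value of 800 nM is estimated, within 300 nM to 2000 nM.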

Compound 3, half-maximal effective concentration: 2120 nM
The estimate for compound 3 lay 2.7-fold (0.42 log units) below the measured number, and the stated range ends below it.
By their numbers in this assay, from the lowest: compound 1; then compounds 3 and 2 (each within the scatter of the next).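

Putting 4-fluoro-3-methylphenyl in place of 3-methoxyphenyl gives a 1.3-fold lower number from compound 2 to compound 3 (0.10 log units; within the scatter) and so the returning fluorine does not by itself bring back the lower number of compound 1. With fluorine present in both, methyl in place of hydrogen on an aromatic carbon gives a 3.1-fold higher number from compound 1 to compound 3 (0.49 log units; beyond the scatter) and this single added methyl separates that pair. Nothing available explains this step. Still open, going by these compounds, is how a chlorine, a hydroxyl or an amine would behave in place of that methyl, and whether a larger ethyl group would move the number further.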